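One More Methyl: What to Expect for Compound 4

This account rests on a few compounds, and the source may have more. Where it says the series, first, only, none or still open, it means among the compounds named here.

Of the compounds shown here, three have been measured in an ADME assay on the whole organism with Oryza sativa as the target, tested at 1 uM; a higher number here means a weaker effect of the compound at the concentration tested, a lower number a stronger effect. Compound 1 `CCc1ccc(NC(=O)N[C@H](C)c2ccccc2)cc1` gives 47%, compound 3 `CC(C)c1ccc(NC(=O)N[C@H](C)c2ccccc2)cc1` gives 79%, and compound 2 `CC(C)c1ccccc1NC(=O)N[C@H](C)c1ccccc1` gives 101%, the highest of the three. From compound 1 to compound 3 the change is methyl in place of hydrogen on a saturated chain carbon bound to an aromatic carbon and a saturated chain carbon, and this step moved the read-out by a number 32 percentage points higher from compound 1 to compound 3 (beyond the scatter). The difference between the cores of compound 1 and compound 2 is not broken down here. Compound 4 `C[C@@H](NC(=O)Nc1ccccc1C(C)(C)C)c1ccccc1` is yet to be measured. It differs from compound 2 by methyl in place of hydrogen on a saturated chain carbon bound to an aromatic carbon and two saturated chain carbons, the same kind of change, though here the place carries two saturated chain carbons rather than one. Because compound 2 already gives 101%, little room remains, so the expected step is a number 1 percentage points lower from compound 2 to compound 4 (within the scatter), smaller than the earlier one. Compound 4 is estimated at 100%, between 85% and 110%.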

Compound 4, a percentage reported as activity, at one concentration (the size of the read-out at that concentration, not a potency): 95%
Compound 4: the middle estimate sits 5 percentage points above what was measured, and the stated range covers the measured number.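

In this assay, replacing isopropyl with tert-butyl gave a number 6 percentage points lower from compound 2 to compound 4 (within the scatter). The same change therefore did not carry over with the same result from one core to the other: the same change on two cores in this assay, a number 32 percentage points higher (beyond the scatter) from compound 1 to compound 3 and a number 6 percentage points lower (within the scatter) from compound 2 to compound 4, 38 percentage points apart, beyond the scatter of two such steps These two pairs show that the step cannot simply be transferred in this series, but they do not show why it differs, and the place of the change also differs, carrying two saturated chain carbons in one pair and one in the other.

The compounds shown leave open how a longer chain or a carboxylic acid at this place would read in this assay. They also leave open whether a third core would follow either step.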